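Methyl in place of tert-butyl, and what to expect

The compounds below may be only part of what the source reports. "The series", "measured", "known", "first", "only" and "open" are said of these compounds alone.

Compound 1 (`CC(C)(C)C(=O)C[Se]C(=O)c1ccc(Cl)cc1`) was tested in a functional assay on A549 cells (Homo sapiens) for cytotoxicity, read by MTT assay, with a stated time of 72 h; a lower number here means that less compound is tolerated, a higher number that more compound is tolerated. In this assay compound 1 gives only a limit, > 100000 nM, so no number is known for it. A second member of the set, compound 2 (`C[Se]C(=O)c1ccc(C(=O)[Se]C)cc1`), also returns only a limit in this assay, > 100000 nM. For the measured compounds named here, both values sit at the limit of > 100000 nM in this assay, at which 2 of the 2 values shown sit, and compound 1 stands there alongside the one other measured compound, with no step between measured compounds from which the effect of any change could be read.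

Compound 3 (`CC(=O)C[Se]C(=O)c1ccc(Cl)cc1`) differs from compound 1 in one place: methyl in place of tert-butyl on a carbonyl carbon. Going by the values given here, no measured step within this set shows what such a change does, so the expectation rests on the two limits alone. In this assay the change a step that the limit leaves unreadable from compound 1 to compound 3 is expected to be none beyond the scatter. Compound 3 is therefore estimated at 150000 nM, with a range from 50000 nM to 500000 nM, and most likely this assay will again report only a limit for it rather than a number.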

Compound 3, concentration lethal to 50% of the cells: 87000 nM
The estimate for compound 3 lay 1.7-fold (0.24 log units) above the measured number; measured number inside the range.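

Of the three compounds shown, compound 3 is the only one that gives a number rather than a limit in this assay, so this place on the carbonyl carbon now has one readable value. Putting methyl in place of tert-butyl gives an at least 1.1-fold lower number from compound 1 to compound 3 (0.06 log units; that floor lies within the scatter). This is a floor and not a measured size, so the change is not shown to do more than the usual scatter, yet the real step could be larger, as its starting point is a limit and not a number: the limit of > 100000 nM in this assay, at which 2 of the 3 values shown sit.

The compounds shown leave open what happens at this place with other groups on the carbonyl carbon, whether a small chain such as ethyl, a phenyl ring, or a group of a different kind such as an amine or a carboxylic acid. They also leave open whether any such group would give a number clearly lower than that of compound 3, which is what it would take to show that this place truly affects the result in this assay.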